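Hydroxy for Morpholin-4-yl on Two Cores: Growth Inhibition Outlook

The compounds below may be only part of what the source reports. "The series", "measured", "known", "first", "only" and "open" are said of these compounds alone.

Three compounds have been run in a functional assay on MDA-MB-231 cells (Homo sapiens) for inhibition, read by sulforhodamine B assay, with a stated time of 72 h; on this read-out higher numbers stand for weaker inhibition of growth and lower numbers for stronger inhibition of growth. Compound 3 `O=C(/C=C/c1ccncc1-c1ccc2ccccc2c1)N1CCOCC1` gives 8980 nM. Compound 1 `O=C(O)/C=C/c1ccncc1-c1ccc2ccccc2c1` reaches only a limit of the assay, > 10000 nM. Compound 2 `O=C(/C=C/c1ccncc1-c1ccc2cc[nH]c2c1)N1CCOCC1`, which carries a different core, likewise reaches only a limit, > 10000 nM. How the core of compound 2 differs from that of compound 3 is not broken down here.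

From compound 3 to compound 1 the change is hydroxy in place of morpholin-4-yl on a carbonyl carbon, and it produces an at least 1.1-fold higher number from compound 3 to compound 1 (0.04 log units; that floor lies within the scatter). Two of the three values sit at the limit of > 10000 nM in this assay, at which 2 of the 3 values shown sit, so the step can only be read as a floor.

Compound 4 `O=C(O)/C=C/c1ccncc1-c1ccc2cc[nH]c2c1` has not yet been measured in this assay. It differs from compound 2 by hydroxy in place of morpholin-4-yl on a carbonyl carbon, the same change in the same place as from compound 3 to compound 1, now made on the other core. The step expected for compound 4 is a step that the limit leaves unreadable from compound 2 to compound 4, set beside the measured at least 1.1-fold higher number from compound 3 to compound 1 (0.04 log units; that floor lies within the scatter). This expectation rests on compound 2 already standing at a limit, > 10000 nM. Compound 4 is therefore estimated at 20000 nM, most likely again only a limit, within 10000 nM to 60000 nM.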

Compound 4, concentration for 50% growth inhibition: > 10000 nM
Compound 4: no number, only a limit (the forecaster's own chance of this, stated with the estimate: 85%); the middle value lies beyond the limit too.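

Compound 2 and compound 4 both stop at a limit in this assay, so no step can be read between them: the limit of > 10000 nM in this assay, at which 3 of the 4 values shown sit.

The compounds shown leave open how far past that limit compound 1, compound 2 and compound 4 lie, and so whether hydroxy in place of morpholin-4-yl acts alike on the two cores.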